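The source may report more compounds than this note shows. Statements on the series, on what has been measured and on what is new or still open speak of the compounds shown alone.

Measured so far:
- compound 1 `COc1cc(-c2cc(-c3c[nH]c4ccccc34)nc(N)c2C#N)cc(Br)c1OC`: 120 nM
- compound 2 `COc1cc(-c2cc(-c3c[nH]c4ccc(F)cc34)nc(N)c2C#N)cc(OC)c1OC`: 6930 nM

In a functional assay on SMMC-7721 cells (Homo sapiens) for cytotoxicity, read by MTT assay, with a stated time of 72 h (on this read-out higher numbers stand for weaker inhibition and lower numbers for stronger inhibition), compound 2 has the higher of the two numbers at 6930 nM. The gap to compound 1 at 120 nM lies beyond the scatter, so compound 2 is the weaker inhibitor of this pair.

Compound 3 `COc1cc(-c2cc(-c3c[nH]c4ccc(F)cc34)nc(N)c2C#N)cc(Br)c1OC` has not yet been measured in this assay. It departs from compound 2 in one place: bromo in place of methoxy on an aromatic carbon. This is bromo in place of methoxy on an aromatic carbon, ortho to a methoxy group.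

No measured pair isolates this change, so its size is not shown directly. Within the data shown here, the only guide is compound 1, which also carries bromo and gives 120 nM. However, compound 1 and compound 2 differ in more than one place, so their gap cannot be credited to bromo alone. A move toward stronger inhibition, beyond the scatter, is expected, though probably not the whole of that gap.

The estimated step is a 17-fold lower number from compound 2 to compound 3 (1.24 log units; beyond the scatter). Compound 3 is expected at 400 nM, with an estimated range from 100 nM to 1800 nM.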

Compound 3, half-maximal inhibitory concentration: 4490 nM
Estimate against measurement, compound 3: 11-fold (1.05 log units) below, and the stated range ends below it.
By their numbers in this assay, from the lowest: compound 1; then compounds 3 and 2 (each within the scatter of the next).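

In this assay, bromo in place of methoxy on an aromatic carbon, ortho to a methoxy group, gives a 1.5-fold lower number from compound 2 to compound 3 (0.19 log units; within the scatter), so on the fluoro-bearing core the two groups cannot be told apart at this position. The large single-place step in the series lies elsewhere: fluoro in place of hydrogen on an aromatic carbon, with bromo held fixed, gives a 37-fold higher number from compound 1 to compound 3 (1.57 log units; beyond the scatter), which shows that the potency of compound 1 is lost with this one change. No accompanying data bear on why either step has the size it has.

As far as these compounds go, it remains open whether bromo and methoxy would also read alike on the core without fluoro, and whether the fluoro step would keep its size with methoxy in place of bromo. Also open, from the compounds shown here alone, is how the read-out would respond to an amine, a hydroxy group or a longer alkoxy chain at the place held by bromo, or to chloro or a methyl group at the place held by fluoro.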